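The compounds below may be only part of what the source reports. "The series", "measured", "known", "first", "only" and "open" are said of these compounds alone.

Working notes on the series. The shared core is varied only at the sulfonamide nitrogen. Among the measured compounds shown here, compound 3 `Cc1ccc(S(=O)(=O)N(CC(=O)NCc2ccc(Cl)cc2)c2cccnc2C)cc1` gives 200 nM in an assay on CHO cells for displacement of a labelled ligand from prostaglandin E2 receptor EP1 subtype (Homo sapiens) (a higher number here means a weaker inhibitor, a lower number a stronger inhibitor), the one plain number among the three measured compounds. Compound 1 `Cc1ccc(S(=O)(=O)N(CC(=O)NCc2ccc(Cl)cc2)c2cccnc2)cc1` reaches only a limit of this assay, < 1000 nM. Compound 2 `Cc1ccc(S(=O)(=O)N(CC(=O)NCc2ccc(Cl)cc2)c2ccccn2)cc1` likewise sits at a limit of this assay, < 1000 nM. Because of the limit of < 1000 nM in this assay, at which 2 of the 3 values shown sit, the steps a step that the limit leaves unreadable from compound 1 to compound 3, a step that the limit leaves unreadable from compound 2 to compound 3 and a step that the two limits leave unreadable from compound 1 to compound 2 cannot be sized. Compound 4 `Cc1ccc(S(=O)(=O)N(CC(=O)NCc2ccc(Cl)cc2)c2ncccc2C)cc1` carries the change (3-methylpyridin-2-yl in place of 2-methylpyridin-3-yl on a sulfonamide nitrogen). For the measured compounds named here, no measured step reads on this swap, and the two measured ring exchanges are unreadable, so no shift beyond the scatter is expected in either direction. Compound 4 is estimated at 300 nM, range 100 nM to 1000 nM, which means an expected step of a 1.5-fold higher number from compound 3 to compound 4 (0.18 log units; within the scatter).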

Compound 4, inhibition constant: 794 nM
Estimate against measurement, compound 4: 2.6-fold (0.42 log units) below; measured number inside the range.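

Working in this assay, the exchange at the sulfonamide nitrogen gives the first readable step of the series, a 4.0-fold higher number from compound 3 to compound 4 (0.60 log units; beyond the scatter). Two groups with the same atoms, joined differently, are therefore told apart at this position. The steps from compound 1 and from compound 2 to compound 4 cannot be read: the limit of < 1000 nM in this assay, at which 2 of the 4 values shown sit.

Going by these compounds, what the methyl group itself contributes on either pyridine ring stays open. Also open, on these data alone, is how a phenyl ring, or an ethyl or methoxy group in place of that methyl, would read at this position.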